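The source may report more compounds than this note shows. Statements on the series, on what has been measured and on what is new or still open speak of the compounds shown alone.

In a functional assay on LOX IMVI cells (Homo sapiens) for inhibition (a higher number here means a weaker inhibitor of growth, a lower number a stronger inhibitor of growth), compound 2 (`NS(=O)(=O)c1ccc(/C=C/c2ccc(O)c(O)c2)cc1`) gives 29900 nM and so lies within the usual scatter of the other two measured compounds: compound 3 (`COc1cccc(/C=C/c2ccc(S(N)(=O)=O)cc2)c1`) at 30700 nM and compound 1 (`COc1cc(/C=C/c2ccc(S(N)(=O)=O)cc2)cc(OC)c1`) at 18200 nM on the same read-out. All three numbers therefore sit in one band, and none of these compounds can be ranked above another.

Compound 4 (`NS(=O)(=O)c1ccc(/C=C/c2ccc(O)cc2)cc1`) has not yet been measured. It differs from compound 2 by one change, hydrogen in place of hydroxy on an aromatic carbon. Going by the values given here, only one measured step bears on this, and only indirectly. It is also a replacement by hydrogen on an aromatic carbon, with methoxy leaving rather than hydroxy, and it gives a 1.7-fold higher number from compound 1 to compound 3 (0.23 log units; within the scatter) in the same test. Among the compounds with values here, no measured pair shows the loss of a hydroxy group itself, so the comparison is an imperfect one.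

On that evidence, no step beyond the scatter is expected in this assay and no direction can be assigned. The expected change is a 1.1-fold lower number from compound 2 to compound 4 (0.03 log units; within the scatter) as an estimate. For compound 4 the estimated value is 28000 nM with an expected range from 12000 nM to 65000 nM in this estimate.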

Compound 4, concentration for 50% growth inhibition: 19100 nM
Compound 4: the middle estimate sits 1.5-fold (0.17 log units) above what was measured; the range from low to high includes it.
By their numbers in this assay, from the lowest: compounds 1, 4, 2 and 3 (each within the scatter of the next).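

In this assay, the removal of a hydroxy group itself can now be read directly, and it gives a 1.6-fold lower number from compound 2 to compound 4 (0.19 log units; within the scatter). The earlier compounds shown here showed only a methoxy group giving way to hydrogen, whereas this pair concerns a hydroxy group on an aromatic carbon, ortho to a hydroxy group and meta to a large group, and shows that hydrogen can stand in its place without a step beyond the scatter. With compound 4 at 19100 nM, all four compounds remain in one band, and no measurement offered here explains the small difference that is seen.

The compounds shown do not reveal whether an amine or a carboxylic acid in the place of this hydroxy group would stay within that band, since every replacement that can be read here is by hydrogen. They also leave open what the loss of the remaining hydroxy group of compound 4 would do, and whether any single change on this ring can move the number beyond the scatter.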